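Halogen swap on the aryl ring of a tetrabromo series

A few compounds are considered here, and "the series" means these few. Any claim that something is new, unique, unknown or untested is made for them only; others in the source may bear on it.

Measured compounds:
compound 1, `OC(CCn1nc2c(Br)c(Br)c(Br)c(Br)c2n1)c1ccc(Br)cc1`: 0%
compound 2, `OC(CCn1nc2c(Br)c(Br)c(Br)c(Br)c2n1)c1ccc(Cl)cc1`: 0%
compound 3, `OC(CCn1nc2c(Br)c(Br)c(Br)c(Br)c2n1)c1ccc(F)cc1`: not yet measured

In a functional assay on CCRF-CEM cells (Homo sapiens) for antiproliferative activity, read by MTT assay, with a stated time of 48 h, tested at 100 uM (on this read-out lower numbers stand for a stronger effect and higher numbers for a weaker effect at the one concentration tested), compound 1 gives 0% and compound 2 gives 0%. Going by the values given here, the one step on record, no change at the digits printed from compound 1 to compound 2 (within the scatter), shows no change at the digits printed. Compound 2 thus stands level with compound 1; neither shows any measurable effect at the single concentration tested.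

Compound 3 carries fluoro in place of chloro on an aromatic carbon. Among the compounds with values here, the only comparison that bears on this change is the step from compound 1 to compound 2, in which one halogen replaced another on the same aromatic carbon and no change at the digits printed from compound 1 to compound 2 (within the scatter) stayed flat. Within the data shown here, nothing in the data suggests that a second such replacement should behave differently, and no other step in this assay is available for comparison.

Compound 3 is therefore expected to move by no change at the digits printed from compound 2 to compound 3 (within the scatter), that is, no step beyond the scatter. For compound 3 the expected value in this assay is 0%, with a range from 0% to 12%.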

Compound 3, a percentage reported as activity, at one concentration (the size of the read-out at that concentration, not a potency): 0%
Estimate against measurement, compound 3: no gap at the digits printed; measured number inside the range.
By their numbers in this assay, from the lowest: compounds 1, 2 and 3 (each within the scatter of the next).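

In this assay, fluoro in place of chloro on an aromatic carbon para to a large group gives no change at the digits printed from compound 2 to compound 3 (within the scatter), and fluoro in place of bromo at the same carbon gives no change at the digits printed from compound 1 to compound 3 (within the scatter). Going by these compounds alone, the series now holds three halogens at this position rather than two, and with compound 3 at 0% the read-out stays flat across bromo, chloro and fluoro, so the earlier single halogen pair is no longer the only comparison on record. No measurement is available that bears on the reason for this flat read-out.

All three compounds carry a halogen on this ring, so the series says nothing about a hydrogen, a methoxy group, an amine or a carboxylic acid at the same carbon, or about a longer chain between the aryl ring and the shared core. From the compounds shown here alone, with a single tested concentration and three level values, it also remains open whether these halogens would separate at lower concentrations in this assay, where the present numbers do not distinguish them.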